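Aryl exchange from compound 3 to compound 4

A few compounds are considered here, and "the series" means these few. Any claim that something is new, unique, unknown or untested is made for them only; others in the source may bear on it.

Measured in a functional assay on MCF7 cells (Homo sapiens) for cytotoxicity, read by MTT assay, with a stated time of 72 h; a higher number here means a weaker inhibitor, a lower number a stronger inhibitor:
- compound 1 `O=C(/C=C/c1ccc([N+](=O)[O-])cc1)Nc1cc2c(Nc3ccc(F)c(Cl)c3)ncnc2cc1O[C@H]1CCOC1`: 26700 nM
- compound 2 `O=C(/C=C/c1cccc(Cl)c1Cl)Nc1cc2c(Nc3ccc(F)c(Cl)c3)ncnc2cc1O[C@H]1CCOC1`: 30100 nM
- compound 3 `O=C(/C=C/c1cc(Br)c(O)c(Br)c1)Nc1cc2c(Nc3ccc(F)c(Cl)c3)ncnc2cc1O[C@H]1CCOC1`: 30600 nM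

Compound 3 cannot be separated from the other two (a 1.1-fold higher number from compound 1 to compound 3 (0.06 log units; within the scatter); a 1.0-fold higher number from compound 2 to compound 3 (0.01 log units; within the scatter)). Compound 4 `COc1ccc(/C=C/C(=O)Nc2cc3c(Nc4ccc(F)c(Cl)c4)ncnc3cc2O[C@H]2CCOC2)c(OC)c1OC` carries 2,3,4-trimethoxyphenyl in place of 3,5-dibromo-4-hydroxyphenyl (2,3,4-trimethoxyphenyl in place of 3,5-dibromo-4-hydroxyphenyl on a double-bonded chain carbon bound to a double-bonded chain carbon). These two steps bear on it, as does the exchange at the same place in a 1.1-fold higher number from compound 1 to compound 2 (0.05 log units; within the scatter); all three stay within the scatter. Within the data shown here, no measured compound carries 2,3,4-trimethoxyphenyl, so this remains an extrapolation. No step beyond the scatter is expected in this assay. The expected change is a 1.1-fold lower number from compound 3 to compound 4 (0.04 log units; within the scatter). Compound 4 is estimated at 28000 nM, with an expected range of 14000 nM to 50000 nM.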

Compound 4, half-maximal inhibitory concentration: 4650 nM
For compound 4 the middle estimate is 6.0-fold (0.78 log units) above the measured one; measured number below the stated range.
By their numbers in this assay, from the lowest: compound 4; then compounds 1, 2 and 3 (each within the scatter of the next).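

In this assay this position on the double-bonded chain carbon proves sensitive to the aryl group, which the three earlier compounds, all within the scatter of one another, did not show: the exchange to 2,3,4-trimethoxyphenyl gives a 6.6-fold lower number from compound 3 to compound 4 (0.82 log units; beyond the scatter), a 6.5-fold lower number from compound 2 to compound 4 (0.81 log units; beyond the scatter) and a 5.7-fold lower number from compound 1 to compound 4 (0.76 log units; beyond the scatter). The step holds against all three leaving groups, whether they carry halogens, a hydroxyl or a nitro group. No measurement on hand accounts for it.

Whether all three methoxy groups are needed stays open, as a single methoxy group on the phenyl ring is not among these compounds. From the compounds shown here alone, how an amine or a carboxylic acid on that ring would compare also stays open.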